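Replacing the Benzyl Ether of Compound 2 with a Carbamate

The compounds below may be only part of what the source reports. "The series", "measured", "known", "first", "only" and "open" are said of these compounds alone.

Compound 2 `CC(C)=CCC/C(C)=C/CC1Cc2c(OCc3ccccc3)cc(=O)n(CCCO)c2CC1(C)C` gives the highest of the three numbers in a functional assay on PANC-1 cells (Homo sapiens) for inhibition, read by MTT assay, with a stated time of 24 h, tested at 10 uM (on this read-out lower numbers stand for less inhibition and higher numbers for more inhibition at the one concentration tested (going by the name of the read-out)), at 46.5%. Compound 1 `CC(C)=CCC1Cc2c(OCc3ccccc3)cc(=O)n(CCCO)c2CC1(C)C` gives -0.3%, and the step of a number 46.8 percentage points higher from compound 1 to compound 2 (beyond the scatter) is large. Compound 3 `CC(C)=CCC/C(C)=C/CC1Cc2c(OCCCNS(=O)(=O)c3ccc([N+](=O)[O-])cc3)cc(=O)n(CCCO)c2CC1(C)C` gives 7.4%. Compound 4 `CC(C)=CCC/C(C)=C/CC1Cc2c(OC(=O)Nc3cccc(F)c3)cc(=O)n(CCCO)c2CC1(C)C` carries a different change: (3-fluorophenyl)carbamoyl in place of benzyl on an oxygen on an aromatic ring. Among the compounds with values here, no measured step bears directly on this group on the ring oxygen; the only known step lies elsewhere on the shared core. The values of compound 2 and compound 3 show only that another replacement on the same oxygen went with a lower number. A downward step is therefore expected, a number 21.5 percentage points lower from compound 2 to compound 4 (beyond the scatter), though with little to rest on. Compound 4 is estimated at 25%, between 0% and 50%.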

Compound 4, a percentage reported as inhibition, at one concentration (the size of the read-out at that concentration, not a potency): 52.3%
Compound 4: the middle estimate sits 27.3 percentage points below what was measured; measured number above the stated range.
By their numbers in this assay, from the lowest: compounds 1 and 3 (each within the scatter of the next); then compounds 2 and 4 (each within the scatter of the next).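

On the oxygen on the aromatic ring, (3-fluorophenyl)carbamoyl in place of benzyl gives a number 5.8 percentage points higher from compound 2 to compound 4 (within the scatter) in this assay. Compound 3 showed only a replacement on this oxygen that went with a lower number, whereas compound 4 shows that a replacement here need not. Benzyl is therefore not the only group on this oxygen that goes with a number of this size. Open, on these data alone, is what phenylcarbamoyl without the fluorine, or ethylcarbamoyl, would give here. No measurement available explains why compound 2 and compound 4 read alike.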